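Removing a methyl group: a small step, twice

This account rests on a few compounds, and the source may have more. Where it says the series, first, only, none or still open, it means among the compounds named here.

Three thiosemicarbazone-type compounds share a pyridine-bearing amidrazone part and differ in the ring attached to the thiocarbonyl and in one methyl group. Compound 1 `Cc1ccnc(/C(N)=N/NC(=S)N2CCN(c3ccccn3)CC2)c1` gives 85.6% in a functional assay on HeLa cells (Homo sapiens) for cytotoxicity, read by MTT assay, with a stated time of 72 h, tested at 100 uM; a lower number here means less inhibition of growth, a higher number more inhibition of growth at the concentration tested. Compound 2 `Cc1ccnc(/C(N)=N/NC(=S)N2CCSCC2)c1` gives 91.6% in this assay, and compound 3 `N/C(=N\NC(=S)N1CCSCC1)c1ccccn1` gives 88.7% in this assay. All three values lie within the usual scatter of one another, so none can be called more or less active than the others.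

From compound 2 to compound 3 the change is hydrogen in place of methyl on an aromatic carbon, and it made a number 2.9 percentage points lower from compound 2 to compound 3 (within the scatter). The difference between the core of compound 1 and the core of compound 2 is not broken down here.

Compound 4 `N/C(=N\NC(=S)N1CCN(c2ccccn2)CC1)c1ccccn1` has not yet been measured in this assay. It arises from compound 1 through (hydrogen in place of methyl on an aromatic carbon), the same change seen between compound 2 and compound 3. Because that change made a number 2.9 percentage points lower from compound 2 to compound 3 (within the scatter), a similarly small step is expected, namely a number 1.6 percentage points lower from compound 1 to compound 4 (within the scatter). Compound 4 is therefore estimated to give 84% in this assay, most likely between 74% and 94%.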

Compound 4, percent growth inhibition at one concentration: 85.6%
The estimate for compound 4 lay 1.6 percentage points below the measured number, and the stated range covers the measured number.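

In this assay, putting hydrogen in place of the methyl group on the core of compound 1 gave no change at the digits printed from compound 1 to compound 4 (within the scatter). Set beside the earlier step on the other core, the same change reads alike on both: the same change on two cores in this assay, a number 2.9 percentage points lower (within the scatter) from compound 2 to compound 3 and no change at the digits printed (within the scatter) from compound 1 to compound 4, 2.9 percentage points apart, within the scatter of two such steps This shows that, on these two cores, the change from 4-methylpyridin-2-yl to pyridin-2-yl made no difference that can be told from scatter, but two cores are a small sample, and a reading at one concentration cannot show whether the compounds would separate at lower concentrations, so it does not show that the step would carry over in the same way to every core in the series.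

The compounds shown carry only methyl or hydrogen at this place, so what a longer chain such as propyl, a methoxy group, an amine or a carboxylic acid would do there remains open. Also open, from the compounds shown here alone, is how the same change would read on a core with a different group attached to the thiocarbonyl.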